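This account rests on a few compounds, and the source may have more. Where it says the series, first, only, none or still open, it means among the compounds named here.

Values so far in a functional assay on HL-60 cells (Homo sapiens) for cytotoxicity, read by MTT assay, with a stated time of 72 h (a higher number here means a weaker inhibitor, a lower number a stronger inhibitor), for the three measured compounds:

compound 1 `O=S(=O)(c1ccccc1)c1nc2ccccc2nc1N1CCCC1` gives 3460 nM
compound 2 `O=S(=O)(c1ccccc1)c1nc2ccccc2nc1N1CCCC(O)C1` gives 3020 nM
compound 3 `COc1ccc(S(=O)(=O)c2nc3ccccc3nc2N2CCCC(O)C2)cc1` gives 3050 nM

Compound 2 at 3020 nM cannot be separated from compound 1 or compound 3, and the three stand level within the scatter.

The next compound is compound 4 `O=S(=O)(c1ccccc1)c1nc2ccccc2nc1N1CCC(O)CC1` with the same atoms as compound 2 joined differently. The change is 4-hydroxypiperidin-1-yl in place of 3-hydroxypiperidin-1-yl on an aromatic carbon and puts 4-hydroxypiperidin-1-yl in place of 3-hydroxypiperidin-1-yl on an aromatic carbon, next to the ring nitrogen.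

Among the measured compounds shown here, two measured steps bear on this. At the same place, a 1.1-fold lower number from compound 1 to compound 2 (0.06 log units; within the scatter) came with 3-hydroxypiperidin-1-yl in place of pyrrolidin-1-yl and stayed within the scatter. The step of a 1.0-fold higher number from compound 2 to compound 3 (0.00 log units; within the scatter) came with methoxy in place of hydrogen on an aromatic carbon and also stayed within the scatter, but it is a change at another place. For the measured compounds named here, no measured pair tests a move of the hydroxy group itself.

In this assay no step beyond the scatter is therefore expected, and no direction can be favoured. The expected step is a 1.0-fold lower number from compound 2 to compound 4 (0.00 log units; within the scatter) and it is only an estimate. For compound 4 the estimated value is 3000 nM with 1400 nM to 6500 nM as its expected range.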

Compound 4, half-maximal inhibitory concentration: 2900 nM
Estimate against measurement, compound 4: 1.0-fold (0.01 log units) above, within the range that was stated.
By their numbers in this assay, from the lowest: compounds 4, 2, 3 and 1 (each within the scatter of the next).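

In this assay, among the compounds shown here, the hydroxy group moves within the ring for the first time, and 4-hydroxypiperidin-1-yl in place of 3-hydroxypiperidin-1-yl gives a 1.0-fold lower number from compound 2 to compound 4 (0.02 log units; within the scatter) and thus no separable change at this position next to the ring nitrogen. Compared directly with pyrrolidin-1-yl, 4-hydroxypiperidin-1-yl gives a 1.2-fold lower number from compound 1 to compound 4 (0.08 log units; within the scatter) and so stands level with the pyrrolidin-1-yl compound, as the 3-hydroxypiperidin-1-yl group does. No supporting measurement is available to account for this level result.

Whether this position can produce a step beyond the scatter remains open, as the compounds shown carry only pyrrolidin-1-yl and hydroxypiperidinyl groups there, and a piperazin-1-yl ring, a carboxylic acid or a longer aminoalkyl chain could respond differently. It is also open whether the methoxy group of compound 3 would stay level when paired with 4-hydroxypiperidin-1-yl, since the compounds shown carry it only with 3-hydroxypiperidin-1-yl.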